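The source may hold more compounds than are shown below. What is called first, only, known or untested is meant among the compounds shown, and "the series" means these compounds.

Measured compounds in a physicochemical assay for solubility, in phosphate buffer, measured as kinetic solubility; a higher number here means a more soluble compound, a lower number a less soluble compound:

Compound 1, `CC(C)C(c1ccc(-c2ccc3cccc(F)c3c2)[nH]c1=O)N1CCCCC1=O`: 23100 nM
Compound 2, `CC(C)C(c1ccc(-c2ccc3cccc(F)c3c2)[nH]c1=O)N1CCNC1=O`: 24900 nM
Compound 3, `CC(C)C(c1ccc(-c2ccc3cccc(F)c3c2)[nH]c1=O)N1CCN/C1=N\C#N`: 25200 nM

Compound 3 has the highest number of the three, but only on paper: its nearest neighbour is compound 2 and the gap is a 1.0-fold higher number from compound 2 to compound 3 (0.01 log units; within the scatter), while the step from compound 1 is a 1.1-fold higher number from compound 1 to compound 3 (0.04 log units; within the scatter), so the three values sit within the scatter of one another and no order among them can be claimed. Compound 4, `CC(C)C(Cc1noc(=O)[nH]1)c1ccc(-c2ccc3cccc(F)c3c2)[nH]c1=O`, has not yet been measured. It differs from compound 3 in one place: a group of 7 heavy atoms (3 carbon, 2 nitrogen, 2 oxygen; one five-membered aromatic ring with 3 hetero atoms) in place of a group of 8 heavy atoms (4 carbon, 4 nitrogen; one five-membered non-aromatic ring with 2 hetero atoms), on a saturated chain carbon bound to an aromatic carbon and a saturated chain carbon.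

Among the measured compounds shown here, three steps bear on this change, since all of them vary the group on the same saturated chain carbon while the shared core is kept. They were a 1.1-fold higher number from compound 1 to compound 2 (0.03 log units; within the scatter), a 1.1-fold higher number from compound 1 to compound 3 (0.04 log units; within the scatter) and a 1.0-fold higher number from compound 2 to compound 3 (0.01 log units; within the scatter), each within the scatter. Across a six-membered ring, a five-membered ring and a five-membered ring carrying a nitrile, the solubility did not move, so the replacement in compound 4 is expected to give no step beyond the scatter either, with the estimated step being a 1.1-fold lower number from compound 3 to compound 4 (0.06 log units; within the scatter). The solubility of compound 4 in this assay is therefore estimated at 22000 nM, with a range from 9000 nM to 50000 nM.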

Compound 4, solubility: 30400 nM
Compound 4: middle estimate off by 1.4-fold (0.14 log units), on the low side; the measured number falls inside the stated range.
By their numbers in this assay, from the lowest: compounds 1, 2, 3 and 4 (each within the scatter of the next).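

In this assay, among the compounds shown here, the place on a saturated chain carbon bound to an aromatic carbon and a saturated chain carbon has now taken a five-membered aromatic ring with 3 hetero atoms, whereas the earlier compounds carried only non-aromatic rings there, yet every step to the new compound stays within the scatter: (a 1.2-fold higher number from compound 3 to compound 4 (0.08 log units; within the scatter)), (a 1.2-fold higher number from compound 2 to compound 4 (0.09 log units; within the scatter)) and (a 1.3-fold higher number from compound 1 to compound 4 (0.12 log units; within the scatter)). The flat picture therefore extends beyond the non-aromatic rings, and all four compounds stand as one group in which no order can be claimed, with even the widest of these steps, the one from the six-membered lactam-bearing compound, not separating from the scatter. Nothing in the data explains why the read-out stays so flat across these groups.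

All the groups shown at this place carry no net charge and sit on an unchanged shared core, so it remains open whether an amine or a carboxylic acid there would give a step beyond the scatter. From the compounds shown here alone, it is equally open whether a longer chain carrying the same five-membered aromatic ring, or a change elsewhere on the shared core, would move the number at all.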